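This account rests on a few compounds, and the source may have more. Where it says the series, first, only, none or still open, it means among the compounds named here.

Measured compounds:
compound 1 `O=S(=O)(NCCCNCc1ccccc1Cl)c1cc(C(F)(F)F)cc(C(F)(F)F)c1` – 10000 nM
compound 2 `COc1ccccc1CNCCCNS(=O)(=O)c1cc(C(F)(F)F)cc(C(F)(F)F)c1` – 2400 nM
compound 3 `O=S(=O)(NCCCNCc1ccccc1)c1cc(C(F)(F)F)cc(C(F)(F)F)c1` – 3200 nM

In a functional assay on HPAC cells (Homo sapiens) for inhibition, read by MTT assay, with a stated time of 72 h (a lower number here means a stronger inhibitor of growth, a higher number a weaker inhibitor of growth), compound 3 stands second highest of the three numbers: it lies close to compound 2, the pair differing by a 1.3-fold higher number from compound 2 to compound 3 (0.12 log units; within the scatter), and well apart from compound 1, as a 3.1-fold lower number from compound 1 to compound 3 (0.49 log units; beyond the scatter) shows. Compound 4 `COc1ccc(CNCCCNS(=O)(=O)c2cc(C(F)(F)F)cc(C(F)(F)F)c2)cc1` arises from compound 3 by methoxy in place of hydrogen on an aromatic carbon. Among the measured compounds shown here, only one measured step involves a methoxy group, a 1.3-fold higher number from compound 2 to compound 3 (0.12 log units; within the scatter), and it falls within the scatter, though compound 2 carries its methoxy elsewhere on the ring. A methoxy entering at the new place is therefore expected to leave the number about where it is, so the expected step is a 1.2-fold lower number from compound 3 to compound 4 (0.09 log units; within the scatter). Compound 4 is estimated at 2600 nM, with a range from 1000 nM to 6500 nM.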

Compound 4, concentration for 50% growth inhibition: 3000 nM
Beside the measured number, compound 4's estimate is 1.2-fold (0.06 log units) below it, and the stated range covers the measured number.
By their numbers in this assay, from the lowest: compounds 2, 4 and 3 (each within the scatter of the next); then compound 1.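

In this assay methoxy in place of hydrogen, para to a large group, gives a 1.1-fold lower number from compound 3 to compound 4 (0.03 log units; within the scatter) and so shows no clear effect at this place on the ring. The 4-methoxyphenyl group in place of 2-methoxyphenyl gives a 1.3-fold higher number from compound 2 to compound 4 (0.10 log units; within the scatter) and so does not set the two methoxy placements apart, whereas in place of 2-chlorophenyl it gives a 3.3-fold lower number from compound 1 to compound 4 (0.52 log units; beyond the scatter) and that gap is a real one. No supporting measurement accompanies these numbers to explain them. From the compounds shown here alone, whether an amine or a carboxylic acid at this place would shift the number remains open.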